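Removing a methoxy group: metabolic stability of compound 3

The source may hold more compounds than are shown below. What is called first, only, known or untested is meant among the compounds shown, and "the series" means these compounds.

Measured so far:
compound 1, `Cc1c(OCCCCOc2cccc(C(=O)O)c2)ccc(C(=O)CC(C)C)c1C`: 29%
compound 2, `COc1ccc(C(=O)O)cc1OCCCCOc1ccc(C(=O)CC(C)C)c(O)c1C`: 5%

In an ADME assay (liver) for metabolic stability, with Liver microsome (Rattus norvegicus) as the target, read by LC-MS, using microsomes and NADPH, with stated times of 5 min and 60 min, tested at 4 uM (a lower number here means that less of the compound is left, a higher number that more of the compound is left), compound 2 gives 5%, the lowest of the two numbers. Compound 1 gives 29%, a gap to compound 2 that lies beyond the usual scatter. Compound 3, `Cc1c(OCCCCOc2cccc(C(=O)O)c2)ccc(C(=O)CC(C)C)c1O`, has not yet been measured. It differs from compound 2 in one place: hydrogen in place of methoxy on an aromatic carbon. Compound 1 also lacks this methoxy group and keeps more of itself, while compound 3 still shares the hydroxyl of compound 2, so the two measured compounds point in different directions. A moderate rise is expected, with the estimated change being a number 7 percentage points higher from compound 2 to compound 3 (within the scatter), partly because compound 1 without the methoxy gives 29%. In this assay compound 3 is expected to give 12%, with a likely range from 3% to 30%.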

Compound 3, percent of the compound remaining: 51%
Compound 3: middle estimate off by 39 percentage points, on the low side; the whole stated range lies below it.
By their numbers in this assay, from the lowest: compound 2; then compound 1; then compound 3.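

In this assay, hydrogen in place of methoxy on an aromatic carbon, para to a carboxy group, gives a number 46 percentage points higher from compound 2 to compound 3 (beyond the scatter) and so shows that this one position can carry a large difference on its own. Hydroxy in place of methyl on an aromatic carbon gives a number 22 percentage points higher from compound 1 to compound 3 (beyond the scatter) and so shows that the hydroxyl shared by compound 2 and compound 3 does not by itself go with a low number. Nothing available gives a reason for either step.

The compounds shown leave open where a fluorine or an amine on that same aromatic carbon would fall relative to compound 2 and compound 3. They also leave open whether methoxy would lower the number as much on the core of compound 1, which has methyl where compound 3 has hydroxy.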